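Changing the group on the amide-type nitrogen of compound 1

The source may report more compounds than this note shows. Statements on the series, on what has been measured and on what is new or still open speak of the compounds shown alone.

Compound 1 `COc1ccc(NC(=O)C(=O)c2cn(C(C)C)c3ccccc23)cn1`: 85 nM
Compound 2 `CC(C)n1cc(C(=O)C(=O)Nc2ccc(C(F)(F)F)nc2)c2ccccc21`: > 10000 nM (a limit of the assay)

Within the data shown here, in a functional assay on FaDu cells (Homo sapiens) for cytotoxicity, read by MTT assay, with a stated time of 72 h (on this read-out lower numbers stand for higher toxicity in this test and higher numbers for lower toxicity in this test), compound 1 gives 85 nM, the only exact number so far. Compound 2 gives > 10000 nM, which is a limit of the assay. Among the measured compounds shown here, the one measured step, an at least 110-fold higher number from compound 1 to compound 2 (2.07 log units; beyond the scatter), came with trifluoromethyl in place of methoxy on an aromatic carbon.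

Compound 3 `COc1nsc(NC(=O)C(=O)c2cn(C(C)C)c3ccccc23)n1` has 3-methoxy-1,2,4-thiadiazol-5-yl in place of 6-methoxypyridin-3-yl on an amide-type nitrogen. Its methoxy remains, but the ring carrying it changes, so the step to compound 2 is only a loose guide. That step, an at least 110-fold higher number from compound 1 to compound 2 (2.07 log units; beyond the scatter), shows that editing this group can cost much, so a smaller move towards a higher number is expected. The expected change is a 3.5-fold higher number from compound 1 to compound 3 (0.55 log units; beyond the scatter). For compound 3 the estimated value is 300 nM, with an expected range of 40 nM to 3000 nM.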

Compound 3, concentration lethal to 50% of the cells: 10400 nM
Compound 3: the middle estimate sits 35-fold (1.54 log units) below what was measured; the whole stated range lies below it.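

Compound 3 keeps the methoxy and changes only the ring that carries it, yet in this assay this gives a 120-fold higher number from compound 1 to compound 3 (2.09 log units; beyond the scatter). Compound 2 had shown the opposite edit, in which the ring stays and the methoxy goes, so a large step now appears whichever of the two parts is changed. Among these three compounds, a methoxy alone is therefore not enough for a low number, and only the complete 6-methoxypyridin-3-yl group of compound 1 gives one.

How far compound 2 and compound 3 truly differ cannot be read, because compound 2 gives only a limit of the assay: the limit of > 10000 nM in this assay, at which 1 of the 3 values shown sits. Going by these compounds, it also remains open whether an amine or a hydroxyl group in place of the methoxy of compound 1 would preserve the low number.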